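The source may report more compounds than this note shows. Statements on the series, on what has been measured and on what is new or still open speak of the compounds shown alone.

In a functional assay on MDA-MB-231 cells (Homo sapiens) for inhibition, read by sulforhodamine B assay, tested at 10 uM (on this read-out higher numbers stand for more inhibition at the one concentration tested (going by the name of the read-out) and lower numbers for less inhibition), compound 1 `CN1CCN(c2ccc(C3=NN(C(=O)CCCl)C(c4ccc(N(C)C)cc4)C3)cc2)CC1` gives 2.4%, compound 2 `Cc1ccc(S(=O)(=O)N2N=C(c3ccc(N4CCN(C)CC4)cc3)CC2c2ccc(N(C)C)cc2)cc1` gives 10.7%, and compound 3 `CN1CCN(c2ccc(C3=NN(S(=O)(=O)c4ccc(C(F)(F)F)cc4)C(c4ccc(N(C)C)cc4)C3)cc2)CC1` gives 12.1%. Compound 3 holds the largest of the three numbers, yet both of its gaps to the others lie within the scatter, so the three cannot be ranked. The step of a number 8.3 percentage points higher from compound 1 to compound 2 (within the scatter) changed a different part of the shared core, and the step of a number 1.4 percentage points higher from compound 2 to compound 3 (within the scatter) swapped a group at the very place now in question; neither moved the number beyond the scatter. Compound 4 `CN1CCN(c2ccc(C3=NN(S(=O)(=O)c4ccc(C#N)cc4)C(c4ccc(N(C)C)cc4)C3)cc2)CC1` differs from compound 3 by cyano in place of trifluoromethyl on an aromatic carbon. Given that the earlier swap at this place from compound 2 to compound 3 gave only a number 1.4 percentage points higher from compound 2 to compound 3 (within the scatter), the expected change in this assay is a number 1.1 percentage points lower from compound 3 to compound 4 (within the scatter), nothing beyond the scatter. Compound 4 is therefore estimated at 11%, within a range from 1% to 22%.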

Compound 4, a percentage reported as inhibition, at one concentration (the size of the read-out at that concentration, not a potency): 99.8%
For compound 4 the middle estimate is 88.8 percentage points below the measured one; the measured number lies above the stated range.
By their numbers in this assay, from the lowest: compounds 1, 2 and 3 (each within the scatter of the next); then compound 4.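

In this assay, for the compounds shown here, this aromatic carbon proves far more sensitive than the earlier compounds suggested: cyano gives a number 87.7 percentage points higher from compound 3 to compound 4 (beyond the scatter) and a number 89.1 percentage points higher from compound 2 to compound 4 (beyond the scatter), although methyl and trifluoromethyl lie within the scatter of each other. With (4-cyanophenyl)sulfonyl in place of (2-chloroethyl)carbonyl on the ring nitrogen, the result is a number 97.4 percentage points higher from compound 1 to compound 4 (beyond the scatter), so the sulfonyl link alone does not account for the jump, since the methyl and trifluoromethyl compounds also carry it. Nothing available explains why cyano stands apart. Going by these compounds, whether other groups on this carbon, such as a nitro group or a carboxylic acid, behave like cyano stays open. A single concentration also leaves the potency of compound 4 unknown.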